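From dipropylamino to (3-chlorophenyl)amino on a shared core

The source may hold more compounds than are shown below. What is called first, only, known or untested is meant among the compounds shown, and "the series" means these compounds.

- compound 1 `O=C1C=C(NCc2ccccc2)C(=O)c2c1nc1n2[C@H]2OC[C@@H](O)[C@H]2OC1` gives > 8000 nM (a limit)
- compound 2 `O=C1C=C(NC2CCCCC2)C(=O)c2c1nc1n2[C@H]2OC[C@@H](O)[C@H]2OC1` gives > 8000 nM (a limit)
- compound 3 `CCCN(CCC)C1=CC(=O)c2nc3n(c2C1=O)[C@H]1OC[C@@H](O)[C@H]1OC3` gives > 16000 nM (a limit)

In a functional assay on MCF7 cells (Homo sapiens) for inhibition, read by sulforhodamine B assay (on this read-out higher numbers stand for weaker inhibition and lower numbers for stronger inhibition), compound 3 gives > 16000 nM as a limit and not as a number. Compound 4 `O=C1C=C(Nc2cccc(Cl)c2)C(=O)c2c1nc1n2[C@H]2OC[C@@H](O)[C@H]2OC1` carries (3-chlorophenyl)amino in place of dipropylamino on a double-bonded ring carbon, counted as (3-chlorophenyl)amino in place of dipropylamino on a double-bonded ring carbon in this change. The closest measured steps are a step that the two limits leave unreadable from compound 1 to compound 3 and a step that the two limits leave unreadable from compound 2 to compound 3 and neither has a readable size. All that can be expected in this assay is weak inhibition, with no firm direction. The expected change is an at least 1.3-fold lower number from compound 3 to compound 4 (0.12 log units; that floor lies within the scatter) and remains a rough estimate. For compound 4 the estimate is 12000 nM with an expected range from 3000 nM to 40000 nM in this test.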

Compound 4, half-maximal inhibitory concentration: 4720 nM
The estimate for compound 4 lay 2.5-fold (0.41 log units) above the measured number, within the range that was stated.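

In this assay, within the data shown here, compound 4 is the only compound here that gives a number and not a limit, so inhibition at this position becomes measurable with an aromatic ring on the amine nitrogen. The swap of dipropylamino for (3-chlorophenyl)amino gives an at least 3.3-fold lower number from compound 3 to compound 4 (0.53 log units; beyond the scatter). 3-Chlorophenyl on the amine nitrogen gives an at least 1.6-fold lower number from compound 2 to compound 4 (0.22 log units; that floor lies within the scatter) and an at least 1.6-fold lower number from compound 1 to compound 4 (0.22 log units; that floor lies within the scatter), and both are only floors set by a limit: the limit of > 8000 nM in this assay, at which 2 of the 4 values shown sit.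

The steps among compound 1, compound 2 and compound 3 cannot be read. A plain phenyl or a methoxyphenyl on that amine nitrogen would help to separate the part played by the chlorine from that of the aromatic ring.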